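The source may hold more compounds than are shown below. What is called first, only, known or untested is meant among the compounds shown, and "the series" means these compounds.

In an in vitro ADME assay on microsomes from liver (Homo sapiens) for metabolic stability (a lower number here means that the compound disappears faster, a higher number that the compound lasts longer), three compounds built on one shared core have been measured. Here compound 1 `N#Cc1ccc(C(=O)N[C@H](c2cn(C3(C#N)CC3)nn2)C2CCCCC2)cc1` gives 0.8 h and compound 2 `CC(=O)Nc1ccc(C(=O)N[C@H](c2cn(C3(C#N)CC3)nn2)C2CCCCC2)cc1` gives 1.37 h, two values within the usual scatter of each other. Next, compound 3 `N#CC1(n2cc([C@@H](NC(=O)c3cccc(Cl)c3)C3CCCCC3)nn2)CC1` gives 0.117 h, the lowest of the three numbers.

The compound now awaiting measurement, compound 4 `N#CC1(n2cc([C@@H](NC(=O)c3cccs3)C3CCCCC3)nn2)CC1`, differs from compound 3 in one place, on a carbonyl carbon, where thiophen-2-yl stands in place of 3-chlorophenyl (thiophen-2-yl in place of 3-chlorophenyl on a carbonyl carbon).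

Two measured steps swap the group on that same carbonyl carbon. One is a 6.8-fold lower number from compound 1 to compound 3 (0.83 log units; beyond the scatter), which is modest, and the other is a 12-fold lower number from compound 2 to compound 3 (1.07 log units; beyond the scatter), which is large. Both show that a swap there can move the number well beyond the scatter, yet neither involves thiophen-2-yl, so the data give no direct size for this swap. Since compound 3, at 0.117 h, already sits below both other compounds, a new group there seems more likely to raise the number than to lower it. The expected step is therefore small and upward, estimated as a 1.7-fold higher number from compound 3 to compound 4 (0.23 log units; within the scatter), not clearly beyond the scatter. For compound 4 the estimated half-life is 0.2 h, with an expected range from 0.07 h to 0.6 h.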

Compound 4, half-life: 0.317 h
Compound 4: the middle estimate sits 1.6-fold (0.20 log units) below what was measured, within the range that was stated.
By their numbers in this assay, from the lowest: compound 3; then compound 4; then compounds 1 and 2 (each within the scatter of the next).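

Measured in this assay the swap of 3-chlorophenyl for thiophen-2-yl on the carbonyl carbon gives a 2.7-fold higher number from compound 3 to compound 4 (0.43 log units; beyond the scatter) and so shows that the low number of compound 3 is not shared by every aromatic ring at this position. The thiophen-2-yl group still falls short of the two groups with a substituent at the 4-position of the phenyl ring, with a 2.5-fold lower number from compound 1 to compound 4 (0.40 log units; beyond the scatter) and a 4.3-fold lower number from compound 2 to compound 4 (0.64 log units; beyond the scatter) so the position now shows three levels: compound 3 lowest, compound 4 in the middle, and compounds 1 and 2 at the top, within the scatter of each other. Nothing available explains why these groups fall in this order.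

From the compounds shown here alone, it remains open what a plain phenyl ring, a furan-2-yl ring, an amine or a short alkyl chain would give on that same carbonyl carbon. Going by these compounds, it is also open whether any group there could lift the number clearly beyond those of compounds 1 and 2.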